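The source may report more compounds than this note shows. Statements on the series, on what has been measured and on what is new or still open speak of the compounds shown alone.

In a toxicity assay on GES1 cells (Homo sapiens) for inhibition, read by MTT assay, with a stated time of 72 h (a lower number here means a stronger inhibitor, a higher number a weaker inhibitor), compound 2 `Cc1cc(N2CC[C@@H](C)[C@@H](N(C)c3ncnc4[nH]ccc34)C2)n2nc(SCc3ccccc3Br)nc2n1` gives > 100000 nM as a limit of the assay and not a number. Compound 1 `C[C@@H]1CCN(c2cc(-c3ccccc3)nc3ncnn23)C[C@@H]1N(C)c1ncnc2[nH]ccc12` gives > 100000 nM as a limit too. Compound 3 `CCc1cc(N2CC[C@@H](C)[C@@H](N(C)c3ncnc4[nH]ccc34)C2)n2ncnc2n1` gives > 100000 nM as a limit as well. All three therefore share the limit of > 100000 nM in this assay, at which 3 of the 3 values shown sit, and compound 2 offers no exact number to start from.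

The change to compound 4 `Cc1ccc(CSc2nc3nc(C)cc(N4CC[C@@H](C)[C@@H](N(C)c5ncnc6[nH]ccc56)C4)n3n2)cc1` is 4-methylphenyl in place of 2-bromophenyl on a saturated chain carbon bound to a sulfur and in words it puts 4-methylphenyl in place of 2-bromophenyl on a saturated chain carbon bound to a sulfur. Going by the values given here, the only measured step is a step that the two limits leave unreadable from compound 1 to compound 3 and it concerns a different group, so it gives no size to carry over. With no readable step to go on, no change beyond the scatter is expected in this assay and no direction can be named. The expected step is a number no higher from compound 2 to compound 4 (the limit leaves the size open) and the assay will most likely report only a limit again. For compound 4 the estimated value is 100000 nM (expected range 50000 nM to 200000 nM).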

Compound 4, half-maximal inhibitory concentration: 82500 nM
Estimate against measurement, compound 4: 1.2-fold (0.08 log units) above, within the range that was stated.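

In this assay, compound 4 gives 82500 nM, the only exact number among the compounds shown, so changing (2-bromobenzyl)sulfanyl to (4-methylbenzyl)sulfanyl yields a value that can be read as a number rather than a limit. The step is an at least 1.2-fold lower number from compound 2 to compound 4 (0.08 log units; that floor lies within the scatter); the true step could be larger, but this floor alone does not show a real change in toxicity to these cells. Compound 2 has only a limit, so the size of the step stays open, and the step between compound 1 and compound 3 also cannot be read: the limit of > 100000 nM in this assay, at which 3 of the 4 values shown sit.

This change swaps the bromine for a methyl and alters where the group sits on the ring, so the two effects cannot be separated; a 4-bromobenzyl or 2-methylbenzyl group would pull them apart. From the compounds shown here alone, how an amine or a carboxylic acid on that ring would read in this assay also remains open.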